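The compounds below may be only part of what the source reports. "The series", "measured", "known", "first", "only" and "open" are said of these compounds alone.

Among the compounds with values here, compound 1 `Cc1cn([C@@H]2O[C@H](CO[Si](C)(C)C(C)(C)C)[C@@]3(OS(=O)(=O)C=C3NCC(=O)C(=O)N3CCC3)[C@H]2O[Si](C)(C)C(C)(C)C)c(=O)n(C)c1=O` sits at the top of the three numbers available so far: in a functional assay on CCRF-CEM cells (Homo sapiens) (on this read-out higher numbers stand for lower toxicity in this test and lower numbers for higher toxicity in this test), compound 1 gives 21600 nM. Its two measured neighbours share the core and differ from it only in the group on the amine nitrogen whose other neighbour is a double-bonded ring carbon. Compound 2 `CCOC(=O)NC(=O)NC1=CS(=O)(=O)O[C@@]12[C@@H](CO[Si](C)(C)C(C)(C)C)O[C@@H](n1cc(C)c(=O)n(C)c1=O)[C@@H]2O[Si](C)(C)C(C)(C)C` gives 3000 nM in this assay, and compound 3 `C=C(C)C(=O)NC(=O)NC1=CS(=O)(=O)O[C@@]12[C@@H](CO[Si](C)(C)C(C)(C)C)O[C@@H](n1cc(C)c(=O)n(C)c1=O)[C@@H]2O[Si](C)(C)C(C)(C)C` gives 1200 nM. Both steps away from compound 1 go downward: a 7.2-fold lower number from compound 1 to compound 2 (0.86 log units; beyond the scatter) and an 18-fold lower number from compound 1 to compound 3 (1.26 log units; beyond the scatter), while between the two acylated compounds a 2.5-fold lower number from compound 2 to compound 3 (0.40 log units; beyond the scatter).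

Compound 4 `Cc1cn([C@@H]2O[C@H](CO[Si](C)(C)C(C)(C)C)[C@@]3(OS(=O)(=O)C=C3NC(=O)c3ccccc3)[C@H]2O[Si](C)(C)C(C)(C)C)c(=O)n(C)c1=O` has not yet been measured. Its change from compound 1 is benzoyl in place of (((azetidin-1-yl)carbonyl)carbonyl)methyl on an amine nitrogen. As in the steps to compound 2 and compound 3, a carbonyl-bearing group takes the place of the (((azetidin-1-yl)carbonyl)carbonyl)methyl on the amine nitrogen, so the two downward steps from compound 1 are the ones that bear on it. Because both a 7.2-fold lower number from compound 1 to compound 2 (0.86 log units; beyond the scatter) and an 18-fold lower number from compound 1 to compound 3 (1.26 log units; beyond the scatter) lie beyond the scatter in the same direction, a downward step beyond the scatter is expected for compound 4 as well, of a size between those two, a 5.4-fold lower number from compound 1 to compound 4 (0.73 log units; beyond the scatter). Compound 4 is therefore estimated at 4000 nM in this assay, with a plausible range from 1500 nM to 12000 nM.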

Compound 4, half-maximal cytotoxic concentration: 4910 nM
Compound 4: the middle estimate sits 1.2-fold (0.09 log units) below what was measured; low and high end bracket the measured number.
By their numbers in this assay, from the lowest: compound 3; then compounds 2 and 4 (each within the scatter of the next); then compound 1.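

The benzoyl group on the amine nitrogen also gives a lower number than the (((azetidin-1-yl)carbonyl)carbonyl)methyl group of compound 1 in this assay (a 4.4-fold lower number from compound 1 to compound 4 (0.64 log units; beyond the scatter)), so among these compounds the downward step does not depend on the carbamoyl unit that compound 2 and compound 3 both carry. On the carbonyl carbon, phenyl in place of (ethoxycarbonyl)amino leaves the two compounds indistinguishable (a 1.6-fold higher number from compound 2 to compound 4 (0.21 log units; within the scatter)), whereas phenyl in place of ((1-methylethenyl)carbonyl)amino gives a separable step (a 4.1-fold higher number from compound 3 to compound 4 (0.61 log units; beyond the scatter)), which leaves compound 3 with the lowest number of the four. No measurement shown here accounts for these differences.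

The compounds shown leave open whether a small acyl group such as acetyl, or a saturated one such as cyclohexanecarbonyl, would fall with compound 4, and whether the free amine would stay closer to compound 1. They also leave open whether these steps would hold on a core with free hydroxyl groups in place of the silyl ethers.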